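A few compounds are considered here, and "the series" means these few. Any claim that something is new, unique, unknown or untested is made for them only; others in the source may bear on it.

Measured compounds:
compound 1, `CCN(Cc1cccs1)C(=O)COc1ccc(C(=O)O)cc1`: "not active" (no number reported)
compound 2, `CCN(Cc1cccs1)C(=O)COc1ccc(OC)cc1`: 120 nM
compound 3, `Cc1ccc(OCC(=O)N(Cc2cccs2)C2CC2)cc1`: 8 nM

All three were tested in an assay on HEK293 cells for agonist activity at transient receptor potential cation channel subfamily M member 8 (Homo sapiens), read by fluorescence and calcium flux, with a stated time of 15 min; on this read-out higher numbers stand for an effect only at larger amounts of compound and lower numbers for an effect already at smaller amounts. Compound 2 gives 120 nM, the higher of the two numbers obtained so far. Compound 3 gives 8 nM, a number far apart from that of compound 2, well beyond the scatter. Compound 1 gives "not active" (no number reported), so no number exists for it.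

Compound 4, `CCN(Cc1cccs1)C(=O)COc1ccc(CO)cc1`, differs from compound 2 in one place: hydroxymethyl in place of methoxy on an aromatic carbon. Among the compounds with values here, no measured pair shows this same change, so its size cannot be read from the data. Within the data shown here, the only hint is compound 1, whose group on an aromatic carbon of a six-membered aromatic ring of carbon only also carries a hydrogen-bond donor and which gives "not active" (no number reported). On that basis the step from compound 2 to compound 4 is expected to be a 3.3-fold higher number from compound 2 to compound 4 (0.52 log units; beyond the scatter), a rise in the number, possibly beyond the scatter. Compound 4 is therefore estimated to give 400 nM, within a range from 100 nM to 2000 nM.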

Compound 4, half-maximal effective concentration: 21900 nM
The estimate for compound 4 lay 55-fold (1.74 log units) below the measured number; measured number above the stated range.
By their numbers in this assay, from the lowest: compound 3; then compound 2; then compound 4.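

In this assay the exchange of methoxy for hydroxymethyl on an aromatic carbon para to a large group gives a 180-fold higher number from compound 2 to compound 4 (2.26 log units; beyond the scatter) and so counts as a large step. The two groups have the same heavy atoms, joined differently, and differ in their count of hydrogen-bond donors, so this position responds strongly even to a change that adds no atoms. Nothing measured here accounts for the size of this step.

The compounds shown do not separate the added hydrogen-bond donor from the different joining of the atoms. Also open, going by these compounds, is how an amine such as aminomethyl or a longer chain such as hydroxyethyl would fare at this position, and whether the same exchange on the core of compound 3 would give a step of similar size.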